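Removing the cyclobutyl from the amino nitrogen of compound 2

A few compounds are considered here, and "the series" means these few. Any claim that something is new, unique, unknown or untested is made for them only; others in the source may bear on it.

Three compounds share one core and differ only in the chain on the ring nitrogen. Compound 1 `CCn1c(-c2ccccc2)nc2c(NC3CCC3)ncnc21` gives 1440 nM in a functional assay on CHO cells for antagonist activity at adenosine receptor A2b (Homo sapiens), read by 33P incorporation, with a stated time of 20 min; a lower number here means a stronger inhibitor, a higher number a weaker inhibitor. Compound 2 `CCCn1c(-c2ccccc2)nc2c(NC3CCC3)ncnc21` gives 774 nM in this assay, and compound 3 `Cn1c(-c2ccccc2)nc2c(NC3CCC3)ncnc21` gives 3730 nM in this assay. Compound 2 has the lowest of the three numbers; the step of a 1.9-fold lower number from compound 1 to compound 2 (0.27 log units; within the scatter) lies within the scatter, while the step of a 4.8-fold higher number from compound 2 to compound 3 (0.68 log units; beyond the scatter) and the step of a 2.6-fold higher number from compound 1 to compound 3 (0.41 log units; beyond the scatter) both fall beyond the scatter.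

Compound 4 `CCCn1c(-c2ccccc2)nc2c(N)ncnc21` differs from compound 2 elsewhere: hydrogen in place of cyclobutyl on a nitrogen on an aromatic ring. For the measured compounds named here, none of the measured steps touches this nitrogen; all three change only the chain on the ring nitrogen, so they give no direct guide to the size of this step. Stripping a ring substituent from an amino group down to a bare amino group is a larger loss of structure than any step seen here, and a weaker inhibitor is expected. The expected step is a 10-fold higher number from compound 2 to compound 4 (1.01 log units; beyond the scatter). Compound 4 is therefore estimated to give 8000 nM in this assay, with a range from 2500 nM to 25000 nM.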

Compound 4, inhibition constant: 1040 nM
For compound 4 the middle estimate is 7.7-fold (0.89 log units) above the measured one; measured number outside the range, below it.
By their numbers in this assay, from the lowest: compounds 2, 4 and 1 (each within the scatter of the next); then compound 3.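

In this assay, putting hydrogen in place of cyclobutyl on the nitrogen on the aromatic ring gives a 1.3-fold higher number from compound 2 to compound 4 (0.13 log units; within the scatter), so compound 2 and compound 4 cannot be told apart by this measurement. For the compounds shown here, the earlier compounds varied only the chain on the ring nitrogen, where a 4.8-fold higher number from compound 2 to compound 3 (0.68 log units; beyond the scatter) is a step that can be read; this pair is the first look at the amino nitrogen, and it shows that, with the chain of compound 2 in place, the whole cyclobutyl ring and its 4 carbon atoms can be removed with no difference beyond the scatter. Nothing measured here explains why this substituent matters so little.

Going by these compounds alone, it remains open whether a bare amino group would behave the same way with the shorter chains of compound 1 and compound 3, as only one pair speaks to this nitrogen. Also open, on these data alone, is what a different group on this nitrogen, such as cyclohexyl, benzyl or acetyl, would do to the number.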